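Replacing Thiophene with Pyridine: An Expectation for Compound 4

The source may hold more compounds than are shown below. What is called first, only, known or untested is meant among the compounds shown, and "the series" means these compounds.

Compound 1 `COc1ccc(C(=O)/C=C/c2cn(-c3ccccc3)nc2-c2ccsc2)cc1OC` — 2800 nM in a functional assay on MCF7 cells (Homo sapiens) for inhibition, read by sulforhodamine B assay, with a stated time of 72 h; a lower number here means a stronger inhibitor, a higher number a weaker inhibitor
Compound 2 `COc1ccc(OC)c(C(=O)/C=C/c2cn(-c3ccccc3)nc2-c2ccsc2)c1` — 400 nM in this assay
Compound 3 `COc1ccc(C(=O)/C=C/c2cn(-c3ccccc3)nc2-c2ccsc2)c(OC)c1` — 9000 nM in this assay

Among the three measured compounds, compound 2 stands lowest in this assay. Compound 1 is its nearest neighbour, the step being a 7.0-fold lower number from compound 1 to compound 2 (0.85 log units; beyond the scatter), and compound 3 is furthest, the step being a 23-fold higher number from compound 2 to compound 3 (1.35 log units; beyond the scatter). Between the other two the step is a 3.2-fold higher number from compound 1 to compound 3 (0.51 log units; beyond the scatter). All three steps vary only the dimethoxyphenyl on the carbonyl carbon, while the thiophen-3-yl stays in place throughout.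

Compound 4 `COc1ccc(OC)c(C(=O)/C=C/c2cn(-c3ccccc3)nc2-c2ccncc2)c1` differs from compound 2 in one place: pyridin-4-yl in place of thiophen-3-yl on an aromatic carbon. Within the data shown here, none of the measured steps touches this position, so none bears on the change, and no size or direction can be read from them. The expectation therefore rests on compound 2 alone and carries a wide range. Compound 4 is expected to lie within the scatter of its parent, a step of a 1.8-fold higher number from compound 2 to compound 4 (0.24 log units; within the scatter). The estimated value of compound 4 in this assay is 700 nM, with a range from 150 nM to 3500 nM.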

Compound 4, half-maximal inhibitory concentration: 1400 nM
Compound 4: middle estimate off by 2.0-fold (0.30 log units), on the low side, and the stated range covers the measured number.
By their numbers in this assay, from the lowest: compound 2; then compounds 4 and 1 (each within the scatter of the next); then compound 3.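

At the aromatic carbon next to the ring nitrogen, the shared core is sensitive to the group it carries: in this assay, pyridin-4-yl in place of thiophen-3-yl gives a 3.5-fold higher number from compound 2 to compound 4 (0.54 log units; beyond the scatter), the only step shown at this position. With the 2,5-dimethoxyphenyl on the carbonyl carbon unchanged, this modest rise belongs to the exchange of a five-membered aromatic ring holding sulfur for a six-membered one holding nitrogen. Nothing measured here accounts for the step.

From the compounds shown here alone, whether the same step would appear with 3,4-dimethoxyphenyl or 2,4-dimethoxyphenyl on the carbonyl carbon stays open, since a single pair speaks to this position. Also open, going by these compounds, is how pyridin-3-yl, furan-2-yl or a morpholine ring at this carbon would compare with thiophen-3-yl and pyridin-4-yl.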